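Halogen exchange on the fused ring of compound 3

The source may report more compounds than this note shows. Statements on the series, on what has been measured and on what is new or still open speak of the compounds shown alone.

Within the data shown here, compound 3 `COc1ccc(-c2cc(-c3ccc(Cl)cc3)n(C3C(=O)Nc4ccc(Br)cc43)n2)cc1` gives 32300 nM in a functional assay on cells (Cancer cell lines, Homo sapiens) for cytotoxicity, read by sulforhodamine B assay, with a stated time of 48 h (on this read-out lower numbers stand for stronger inhibition of growth and higher numbers for weaker inhibition of growth), the lowest number of the three measured so far. Compound 2 `O=C1N=C(N2N=C(c3ccc4ccccc4c3)CC2c2ccc(Cl)cc2)S/C1=C1/C(=O)Nc2ccccc21` gives 42100 nM in this assay, within the scatter of compound 3, while compound 1 `COc1ccc(C2=NN(C3=NC(=O)/C(=C4\C(=O)Nc5ccccc54)S3)C(c3ccc(Cl)cc3)C2)cc1` gives 100000 nM in this assay, a gap beyond the scatter. Among the measured compounds shown here, the only single-change step measured, a 2.4-fold lower number from compound 1 to compound 2 (0.38 log units; beyond the scatter), sits on the core of compound 1 and does not bear on the change now considered. Compound 4 `COc1ccc(-c2cc(-c3ccc(Cl)cc3)n(C3C(=O)Nc4ccc(Cl)cc43)n2)cc1` differs from compound 3 by chloro in place of bromo on an aromatic carbon. For the measured compounds named here, no measured step tests such a halogen exchange, so the expected step is a 1.0-fold lower number from compound 3 to compound 4 (0.00 log units; within the scatter), none beyond the scatter in this assay. Compound 4 is therefore expected to give 32000 nM, with a range from 14000 nM to 70000 nM.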

Compound 4, concentration for total growth inhibition: 13200 nM
The estimate for compound 4 lay 2.4-fold (0.38 log units) above the measured number; measured number below the stated range.
By their numbers in this assay, from the lowest: compound 4; then compounds 3 and 2 (each within the scatter of the next); then compound 1.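

In this assay the halogen on this aromatic carbon of the fused system is not a neutral site: chloro in place of bromo gives a 2.4-fold lower number from compound 3 to compound 4 (0.39 log units; beyond the scatter) with the rest of the molecule unchanged. Among these compounds, the earlier compounds offered no test of this position, and this pair is the first to show that the read-out responds to it. No measurement at hand explains the step.

From the compounds shown here alone, whether fluoro, a methoxy group or an amine on this carbon would shift the number further remains open. So does whether the same exchange would carry the same step on a compound with a different core.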